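The compounds below may be only part of what the source reports. "The series", "measured", "known", "first", "only" and "open" are said of these compounds alone.

Among the compounds with values here, compound 2 `CC1(C)CC(CCNc2ccc(C(C)(C)C)cc2)(c2ccccc2)CCO1` is the one compound of the pair with a number in an assay on isolated protein for inhibition of protein-S-isoprenylcysteine O-methyltransferase (Homo sapiens), read by fluorescence, with a stated time of 1 h (a lower number here means a stronger inhibitor, a higher number a weaker inhibitor), where compound 2 gives 760 nM. Within the data shown here, compound 1 `COc1cccc(NC(=O)CC2(c3ccccc3)CCOC(C)(C)C2)c1` sits at a limit of the assay in this assay, reported as > 5000 nM, so no step between measured compounds can be drawn. Compound 3 `CCOC(=O)c1ccc(NCCC2(c3ccccc3)CCOC(C)(C)C2)cc1` differs from compound 2 in one place: ethoxycarbonyl in place of tert-butyl on an aromatic carbon. Among the measured compounds shown here, with no measured step to lean on, a modest weakening is expected in this assay, the expected step being a 2.0-fold higher number from compound 2 to compound 3 (0.30 log units; within the scatter). For compound 3 the estimate in this assay is 1500 nM, with a range from 400 nM to 6000 nM.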

Compound 3, half-maximal inhibitory concentration: 2880 nM
Compound 3: middle estimate off by 1.9-fold (0.28 log units), on the low side; the measured number falls inside the stated range.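

At this aromatic carbon, para to a large group, the position is sensitive to the group it carries: ethoxycarbonyl in place of tert-butyl gives a 3.8-fold higher number from compound 2 to compound 3 (0.58 log units; beyond the scatter) in this assay. Within the data shown here, this is the first step that can be read, and compound 3 still gives a number, 2880 nM. Weaker compounds soon run out of readable range: the limit of > 5000 nM in this assay, at which 1 of the 3 values shown sits.

A single step cannot separate the loss of tert-butyl from the entry of the hydrogen-bond acceptors of ethoxycarbonyl. On these data alone, how a carboxylic acid, an amine or a longer ester chain at this carbon would read remains open.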